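The source may hold more compounds than are shown below. What is called first, only, known or untested is meant among the compounds shown, and "the series" means these compounds.

Measured so far:
compound 1 `COc1ccc(C2CC(c3ccc(Br)cc3)=NN2C(=O)c2ccc3c(c2)OCCO3)cc1`: 5680 nM
compound 2 `O=C(c1ccc2c(c1)OCCO2)N1N=C(c2ccc(Br)cc2)CC1c1cccc(F)c1`: 810 nM

In a functional assay on WM 266-4 cells (Homo sapiens) for inhibition, read by MTT assay, with a stated time of 24 h (on this read-out lower numbers stand for stronger inhibition of growth and higher numbers for weaker inhibition of growth), compound 2 gives the lowest of the two numbers; compound 1 sits at 5680 nM, and the step of a 7.0-fold lower number from compound 1 to compound 2 (0.85 log units; beyond the scatter) is the only one on record. Compound 3 `O=C(c1ccc2c(c1)OCCO2)N1N=C(c2ccc(Br)cc2)CC1c1ccc(F)cc1` is not yet measured. It differs from compound 2 only in the group on the saturated ring carbon: 4-fluorophenyl in place of 3-fluorophenyl on a saturated ring carbon. Within the data shown here, no measured step moves the fluorine within the ring; the single step of a 7.0-fold lower number from compound 1 to compound 2 (0.85 log units; beyond the scatter) replaces 4-methoxyphenyl with 3-fluorophenyl and so changes the substituent and its place together, which does not separate the two effects. With nothing more to go on, the expected step of a 1.5-fold higher number from compound 2 to compound 3 (0.17 log units; within the scatter) is small and may well fall within the scatter, with a slight lean toward a higher number. Compound 3 is therefore estimated at 1200 nM, with a range of 400 nM to 4000 nM in this assay.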

Compound 3, concentration for 50% growth inhibition: 3260 nM
Estimate against measurement, compound 3: 2.7-fold (0.43 log units) below; the measured number falls inside the stated range.
By their numbers in this assay, from the lowest: compound 2; then compounds 3 and 1 (each within the scatter of the next).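

In this assay, the shift from 3-fluorophenyl to 4-fluorophenyl on the saturated ring carbon gives a 4.0-fold higher number from compound 2 to compound 3 (0.60 log units; beyond the scatter) and leaves the atom count unchanged, so the place of the fluorine alone separates this pair. The change of fluoro for methoxy on an aromatic carbon gives a 1.7-fold lower number from compound 1 to compound 3 (0.24 log units; within the scatter) and stays within the scatter, so the earlier 7.0-fold lower number from compound 1 to compound 2 (0.85 log units; beyond the scatter) is not matched by a 4-substituted fluorophenyl and, among these three compounds, the lower number goes only with 3-fluorophenyl. No measurement at hand accounts for this difference.

On these data alone, it remains open whether the lower number depends on fluorine itself or would also hold with another group in the same place, such as chloro, methoxy or an amine on a 3-substituted phenyl. These three compounds also say nothing about a second fluorine on the same phenyl ring or about a carboxylic acid there.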